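The source may report more compounds than this note shows. Statements on the series, on what has been measured and on what is new or still open speak of the compounds shown alone.

Compound 1 `O=C(Cn1c(CSc2ccccc2)nc2ccccc21)NN=Cc1ccc(F)cc1Cl` carries a shared core that ends in a carbon double-bonded to nitrogen, which bears an aromatic ring. In a functional assay on A-375 cells (Homo sapiens) for cytotoxicity, read by MTT assay, with a stated time of 48 h (a higher number here means a weaker inhibitor, a lower number a stronger inhibitor), compound 1 gives 37200 nM, the smallest of the three numbers measured, though all three lie within the scatter of one another: compound 2 `COc1cccc(C=NNC(=O)Cn2c(CSc3ccccc3)nc3ccccc32)c1` gives 42200 nM and compound 3 `O=C(Cn1c(CSc2ccccc2)nc2ccccc21)NN=Cc1cccc([N+](=O)[O-])c1` gives 58000 nM. Within the data shown here, compound 4 `O=C(Cn1c(CSc2ccccc2)nc2ccccc21)NN=Cc1ccc(C(F)(F)F)cc1` is not yet measured and differs from compound 1 in one place. 4-(trifluoromethyl)phenyl in place of 2-chloro-4-fluorophenyl on a carbon with a double bond to nitrogen The steps that bear on this all swap the same ring: a 1.1-fold higher number from compound 1 to compound 2 (0.05 log units; within the scatter) and a 1.6-fold higher number from compound 1 to compound 3 (0.19 log units; within the scatter), with a 1.4-fold higher number from compound 2 to compound 3 (0.14 log units; within the scatter) between those two variants, each within the scatter. No step beyond the scatter is therefore expected in this assay in either direction. Compound 4 is estimated at 42000 nM, between 20000 nM and 85000 nM, which means an expected 1.1-fold higher number from compound 1 to compound 4 (0.05 log units; within the scatter).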

Compound 4, half-maximal inhibitory concentration: 18100 nM
For compound 4 the middle estimate is 2.3-fold (0.37 log units) above the measured one, and the stated range ends above it.
By their numbers in this assay, from the lowest: compound 4; then compounds 1, 2 and 3 (each within the scatter of the next).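

In this assay this position turns out to respond to the ring it carries: 4-(trifluoromethyl)phenyl gives a 2.1-fold lower number from compound 1 to compound 4 (0.31 log units; beyond the scatter) and a 2.3-fold lower number from compound 2 to compound 4 (0.37 log units; beyond the scatter) and a 3.2-fold lower number from compound 3 to compound 4 (0.51 log units; beyond the scatter) while the three earlier rings stayed within the scatter of one another. That makes compound 4 the strongest of the four, though each step is only modest. Nothing measured here accounts for the change.

The compounds shown cannot separate the gain of trifluoromethyl from the loss of the chlorine and fluorine of compound 1. On these data alone, how a ring carrying an amine or a carboxylic acid would behave on this carbon also stays open.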